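This account rests on a few compounds, and the source may have more. Where it says the series, first, only, none or still open, it means among the compounds named here.

Measured so far in a functional assay on HCT-116 cells (Homo sapiens) for cytotoxicity, read by MTT assay, with a stated time of 24 h; a lower number here means a stronger inhibitor, a higher number a weaker inhibitor:
- compound 1, `COc1ccc(/C=C\C(=O)O)c(OCc2cn(-c3ccccc3C#N)nn2)c1CC=C(C)C`: 38300 nM
- compound 2, `COc1ccc(/C=C\C(=O)O)c(OCc2cn(-c3ccc(NC(C)=O)cc3)nn2)c1CC=C(C)C`: "not determined" (no result reported)
- compound 3, `COc1ccc(/C=C\C(=O)O)c(OCc2cn(-c3ccc(CO)cc3)nn2)c1CC=C(C)C`: 31700 nM

Compound 3 stands at the lowest of the two numbers shown, with compound 1 as its nearest neighbour; the step of a 1.2-fold lower number from compound 1 to compound 3 (0.08 log units; within the scatter) is within the scatter, so the two are not to be ranked against each other. Compound 2 carries no number and gives no bearing.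

The next compound is compound 4, `COc1ccc(/C=C\C(=O)O)c(OCc2cn(-c3cccnc3Cl)nn2)c1CC=C(C)C`. Relative to compound 3 the change is 2-chloropyridin-3-yl in place of 4-(hydroxymethyl)phenyl on an aromatic nitrogen. For the measured compounds named here, the one measured step that resembles it is the swap of the group on the same aromatic nitrogen from compound 1 to compound 3, a 1.2-fold lower number from compound 1 to compound 3 (0.08 log units; within the scatter), which stayed within the scatter. Going by the values given here, no step involving a ring with a hetero atom at this position has been measured, so the bearing is indirect. On that single precedent, no step beyond the scatter is expected in this assay for compound 4, in either direction.

Compound 4 is therefore estimated at 35000 nM, with a range from 15000 nM to 80000 nM. The expected step is a 1.1-fold higher number from compound 3 to compound 4 (0.04 log units; within the scatter).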

Compound 4, half-maximal inhibitory concentration: 23000 nM
Compound 4: the middle estimate sits 1.5-fold (0.18 log units) above what was measured, and the stated range covers the measured number.
By their numbers in this assay, from the lowest: compounds 4, 3 and 1 (each within the scatter of the next).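

In this assay, the group on the aromatic nitrogen now changes to a six-membered aromatic ring with a hetero atom and a chlorine: 2-chloropyridin-3-yl in place of 4-(hydroxymethyl)phenyl gives a 1.4-fold lower number from compound 3 to compound 4 (0.14 log units; within the scatter), and in place of 2-cyanophenyl it gives a 1.7-fold lower number from compound 1 to compound 4 (0.22 log units; within the scatter). For the compounds shown here, the earlier pair compared only rings of carbon, so this is the first sign that a hetero atom in this ring, together with the loss of the hydrogen-bond donor of the 4-(hydroxymethyl)phenyl group, leaves the number within the scatter; compound 1, compound 3 and compound 4 cannot be ranked against one another. No measurement at hand accounts for these small steps.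

Still open, as far as these compounds go, is whether any group on this nitrogen gives a step beyond the scatter, for instance an aromatic ring bearing an amine or a carboxylic acid, or a saturated alkyl chain in place of the aromatic ring. Compound 2 has no number and gives no reading for its acetamido group, and the shown compounds say nothing on an ester in place of the carboxylic acid of the shared core.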